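The source may hold more compounds than are shown below. What is called first, only, known or untested is meant among the compounds shown, and "the series" means these compounds.

Measured so far:
- Compound 1 `O=C(COc1ccc(C(=O)/C=C/c2ccccc2Cl)cc1)N[C@H]1CCOC1=O` gives 27100 nM
- Compound 2 `CCCCCCCCCCSC(=S)N[C@H]1CCOC1=O` gives > 64000 nM (a limit, not a number)

Going by the values given here, in a functional assay on MGC-803 cells (Homo sapiens) for antiproliferative activity, read by MTT assay, with a stated time of 72 h (on this read-out higher numbers stand for weaker inhibition and lower numbers for stronger inhibition), compound 1 holds the only actual number, 27100 nM, so it is the sole fixed point for comparison. The entry for compound 2 is only a limit.

Compound 3 `O=C(COc1ccc(C(=O)/C=C/c2cccc(Br)c2)cc1)N[C@H]1CCOC1=O` keeps the core of compound 1 and differs in one place: 3-bromophenyl in place of 2-chlorophenyl on a double-bonded chain carbon bound to a double-bonded chain carbon. It carries 3-bromophenyl in place of 2-chlorophenyl on a double-bonded chain carbon bound to a double-bonded chain carbon.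

Among the compounds with values here, no measured pair shows what such a swap does in this assay, so no shift beyond the usual scatter is expected, and no direction can be favoured. The expected change is thus small, a 1.1-fold lower number from compound 1 to compound 3 (0.04 log units; within the scatter). For compound 3 the estimated value is 25000 nM, with an expected range of 10000 nM to 60000 nM.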

Compound 3, half-maximal inhibitory concentration: 11900 nM
Compound 3: middle estimate off by 2.1-fold (0.32 log units), on the high side; low and high end bracket the measured number.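

In this assay, going by these compounds alone, putting 3-bromophenyl in place of 2-chlorophenyl on a double-bonded chain carbon bound to a double-bonded chain carbon gives a 2.3-fold lower number from compound 1 to compound 3 (0.36 log units; beyond the scatter), so this is the first sign that activity responds to a change at this position. The step is modest, and the halogen and its place on the ring change together, so this one pair cannot show which of the two matters. Nothing measured among these compounds accounts for the shift.

From the compounds shown here alone, it remains open how 3-chlorophenyl or 2-bromophenyl would compare, and these two groups could separate the effect of the halogen from that of its place on the ring. Also open, going by these compounds, is how far the trend extends, for example to a plain phenyl or to a phenyl carrying an amine or a carboxylic acid.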